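The source may report more compounds than this note shows. Statements on the series, on what has been measured and on what is new or still open speak of the compounds shown alone.

Compound 1: `COc1ccc(OC)c(/C=C/c2nnc(Nc3ccc(Cl)cc3)o2)c1`, in a functional assay on RXF 393 cells (Homo sapiens) for antiproliferative activity, read by sulforhodamine B assay, with a stated time of 48 h (on this read-out lower numbers stand for higher toxicity in this test and higher numbers for lower toxicity in this test), compound 1 gives 56100 nM.
Compound 2: `COc1ccc(OC)c(/C=C/C(=O)N/N=C/c2ccc(Cl)cc2)c1`, in this assay compound 2 gives > 100000 nM, which is a limit of the assay and not a number.

Where compound 2 stands on the numbers shown is therefore only partly known: it sits at the limit of > 100000 nM in this assay, at which 1 of the 2 values shown sits, so it can be placed only as the less toxic of the two measured compounds, with no number of its own. Compound 3, `COc1ccc(OC)c(/C=C/C(=O)N/N=C/c2ccccc2)c1`, differs from compound 2 by hydrogen in place of chloro on an aromatic carbon. For the measured compounds named here, no step between measured compounds is available for this change. Since compound 2 already rests at the limit, the step from compound 2 to compound 3 in this assay is expected to be none beyond the scatter, most likely leaving compound 3 at the limit as well; this expectation is written as a step that the limit leaves unreadable from compound 2 to compound 3. For compound 3 in this assay the estimate is 150000 nM, within a range from 60000 nM to 400000 nM.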

Compound 3, concentration lethal to 50% of the cells: > 100000 nM
Compound 3 was reported as a limit; the forecaster's own chance of this, stated with the estimate: 80%; the middle value is on the limit's open side.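

For the compounds shown here, no step from compound 2 to compound 3 can be read, because both results are limits of the assay and not numbers: the limit of > 100000 nM in this assay, at which 2 of the 3 values shown sit. The compounds shown leave open whether 4-chlorophenyl and phenyl differ at all in this assay, where neither compound 2 nor compound 3 has a number of its own.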